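From furan-3-yl to 1-benzofuran-2-yl on the methyl compound

This account rests on a few compounds, and the source may have more. Where it says the series, first, only, none or still open, it means among the compounds named here.

In a functional assay on HCT-116 cells (Homo sapiens), read by MTT assay, with a stated time of 72 h (on this read-out higher numbers stand for weaker inhibition and lower numbers for stronger inhibition), compound 3 (`Cc1ncnc2c1c(-c1ccoc1)cn2[C@@H]1O[C@H](CO)[C@@H](O)[C@H]1O`) reads > 20000 nM, which is a limit and not a number. Compound 2 (`CNc1ncnc2c1c(-c1ccoc1)cn2[C@@H]1O[C@H](CO)[C@@H](O)[C@H]1O`) reads > 20000 nM, which is also a limit. Compound 3 therefore stands at the limit of > 20000 nM in this assay, at which 2 of the 3 values shown sit, with no readable number of its own. Compound 1 (`COc1ncnc2c1c(-c1cc3ccccc3o1)cn2[C@@H]1O[C@H](CO)[C@@H](O)[C@H]1O`), which carries 1-benzofuran-2-yl, gives 14500 nM in this assay. Compound 4 (`Cc1ncnc2c1c(-c1cc3ccccc3o1)cn2[C@@H]1O[C@H](CO)[C@@H](O)[C@H]1O`) differs from compound 3 by one exchange: 1-benzofuran-2-yl in place of furan-3-yl on an aromatic carbon. For the measured compounds named here, the only measured step, a step that the two limits leave unreadable from compound 2 to compound 3, concerns a different place and supplies no size. Going by the values given here, no measured pair isolates this exchange, so the expectation rests on compound 1 at 14500 nM, the only readable value. A modest gain in inhibition is expected, although a reading at the limit remains possible. The expected step is an at least 2.0-fold lower number from compound 3 to compound 4 (0.30 log units; that floor lies within the scatter). Compound 4 is estimated at 10000 nM, with an expected range of 3000 nM to 20000 nM.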

Compound 4, half-maximal inhibitory concentration: > 20000 nM
Compound 4 was reported as a limit; the forecaster's own chance of this, stated with the estimate: 40%; middle value at least 2.0-fold (0.30 log units) from the limit.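

In this assay, 1-benzofuran-2-yl in place of furan-3-yl on the methyl compound yields no readable value: compound 4 is reported as a limit, as compound 3 is, and the steps between limits cannot be read. For the compounds shown here, with 1-benzofuran-2-yl kept, methyl in place of methoxy gives an at least 1.3-fold higher number from compound 1 to compound 4 (0.13 log units; that floor lies within the scatter), so the two compounds cannot be put in order, and the methoxy group cannot be credited with the one readable value. The added six-membered aromatic ring therefore brings no measurable gain on the methyl compound, and the series now gathers at one end: the limit of > 20000 nM in this assay, at which 3 of the 4 values shown sit.

As far as these compounds go, whether methoxy with furan-3-yl, or methylamino with 1-benzofuran-2-yl, gives a readable value remains open. Also open, from the compounds shown here alone, is what an amine or a carboxylic acid on the six-membered aromatic ring of 1-benzofuran-2-yl would do.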